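Replacing an open urea chain by an acetamidopyrrolidine ring

The source may hold more compounds than are shown below. What is called first, only, known or untested is meant among the compounds shown, and "the series" means these compounds.

Compound 1 `CCCC(=O)NCCCc1cccc2oc(CCCCc3ccccc3)cc12`: 16 nM
Compound 2 `CCNC(=O)NCCCc1cccc2oc(CCCCc3ccccc3)cc12`: 21 nM

Both compounds were tested in an assay on NIH3T3 cells for binding affinity to melatonin receptor type 1A (Homo sapiens); a higher number here means a weaker inhibitor, a lower number a stronger inhibitor. Compound 2 gives the higher of the two numbers, but the gap to compound 1 is small: a 1.3-fold higher number from compound 1 to compound 2 (0.12 log units; within the scatter), so the two cannot be told apart. Compound 3 `CC(=O)N[C@H]1CCN(c2cccc3oc(CCCCc4ccccc4)cc23)C1` is built from compound 2 by one change: 3-acetamidopyrrolidin-1-yl in place of 3-((ethylcarbamoyl)amino)propyl on an aromatic carbon. Going by the values given here, the only measured step swaps one group for another on a carbonyl carbon while the open chain stays the same; it says nothing about closing that chain into a ring with a different point of attachment to the shared core. Among the compounds with values here, no measured step therefore bears on the present change, and the direction is open. The expected step is a moderate weakening, a 2.4-fold higher number from compound 2 to compound 3 (0.38 log units; beyond the scatter), with a wide range. For compound 3 the estimate in this assay is 50 nM, between 8 nM and 300 nM.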

Compound 3, inhibition constant: 22 nM
The estimate for compound 3 lay 2.3-fold (0.36 log units) above the measured number, within the range that was stated.
By their numbers in this assay, from the lowest: compounds 1, 2 and 3 (each within the scatter of the next).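

In this assay the open 3-((ethylcarbamoyl)amino)propyl chain can give way to the 3-acetamidopyrrolidin-1-yl ring with no readable effect (a 1.0-fold higher number from compound 2 to compound 3 (0.02 log units; within the scatter)), and the same holds against the open chain of compound 1 (a 1.4-fold higher number from compound 1 to compound 3 (0.14 log units; within the scatter)). This aromatic carbon of the shared core therefore tolerates a five-membered non-aromatic ring with a defined stereocentre in place of a flexible chain, a structural change the earlier pair did not test. Nothing at hand explains why the ring and the open chains give such similar numbers.

The compounds shown leave open whether the mirror-image form of the pyrrolidine would give a similar number, and whether a six-membered piperidine ring would fit as well. They also cannot say whether the acetamido group matters, for example compared with a plain amine on the ring.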